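The compounds below may be only part of what the source reports. "The series", "measured", "known", "first", "only" and "open" are said of these compounds alone.

Measured compounds:
- compound 1 `CCCC1=C(C(=O)OCC)C(c2cccc([N+](=O)[O-])c2)C(C(=O)OCC)=C(C)N1`, in a functional assay on HEK293 cells for antagonist activity at Voltage-dependent L-type calcium channel subunit alpha-1D (Rattus norvegicus), read by FLIPR (on this read-out higher numbers stand for weaker inhibition and lower numbers for stronger inhibition), compound 1 gives 105 nM
- compound 2 `CCCCC1=C(C(=O)OCC)C(c2cccc([N+](=O)[O-])c2)C(C(=O)OCC)=C(C)N1`, compound 2 gives 20 nM
- compound 3 `CCOC(=O)C1=C(C)NC(COC)=C(C(=O)OC)C1c1ccccc1[N+](=O)[O-]`, compound 3 gives 790 nM

Among these three, compound 3 gives the highest number, so it is the weakest inhibitor of the set. The gap from compound 3 down to compound 1 lies beyond the scatter, and the gap down to compound 2 is wider still.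

Compound 4 `CCOC(=O)C1=C(C)NC(COC)=C(C(=O)OC)C1c1cccc([N+](=O)[O-])c1` keeps every atom of compound 3 but joins them differently: 3-nitrophenyl in place of 2-nitrophenyl on a saturated ring carbon. The nitro group thus moves from one ring position to another on the aromatic ring attached to the saturated ring carbon of the shared core.

Going by the values given here, the only measured step in this set is a 5.3-fold lower number from compound 1 to compound 2 (0.72 log units; beyond the scatter), which adds a methyl on a chain and does not touch the nitrophenyl group, so it does not bear on the change from compound 3 to compound 4. Compounds 1 and 2 both carry 3-nitrophenyl and give lower numbers than compound 3, but they also differ from compound 3 at several other places, so their values only hint at the direction. Compound 4 is therefore expected, with wide uncertainty, to show a modest step toward stronger inhibition, a 2.6-fold lower number from compound 3 to compound 4 (0.42 log units; beyond the scatter). The estimate for compound 4 in this assay is 300 nM, within a range from 80 nM to 1200 nM.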

Compound 4, half-maximal inhibitory concentration: 96 nM
The estimate for compound 4 lay 3.1-fold (0.49 log units) above the measured number; low and high end bracket the measured number.
By their numbers in this assay, from the lowest: compound 2; then compounds 4 and 1 (each within the scatter of the next); then compound 3.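

Swapping 2-nitrophenyl for 3-nitrophenyl on the saturated ring carbon gives an 8.2-fold lower number from compound 3 to compound 4 (0.92 log units; beyond the scatter) in this assay and shifts the result toward stronger inhibition. Compounds 1 and 2 also carry 3-nitrophenyl, but they differ from compound 3 in several places, whereas compound 3 and compound 4 isolate this one change and show that the nitro group's position on the aromatic ring matters on this core, even though the two groups have the same atoms and the same counts of donors and acceptors. Nothing measured here explains why this position matters.

On these data alone, it remains open whether a plain phenyl, or a nitrile or chlorine in place of the nitro group, would give a stronger or weaker inhibitor. As far as these compounds go, whether the same move has a similar effect on the cores of compound 1 and compound 2 also remains open.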